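The compounds below may be only part of what the source reports. "The series", "measured", "known", "first", "only" and "open" are said of these compounds alone.

Going by the values given here, compound 2 `COc1cc(OC)c2c(=O)cc(C(=O)Nc3ccc(Oc4ccc([N+](=O)[O-])cc4)cc3)[nH]c2c1` is, of the two compounds measured, the only one that gives a number in a functional assay on KOPN-8 cells (Homo sapiens) for antiproliferative activity, with a stated time of 72 h; a lower number here means that less compound is needed, a higher number that more compound is needed for the effect: compound 2 gives 20500 nM. Compound 1 `COc1ccc(-c2cc(=O)c3c(OC)cc(OC)cc3n2S(=O)(=O)c2ccc(C)cc2)cc1` is shown only as a limit of the assay, and in this assay compound 1 gives > 44800 nM. So compound 2 stands as the one measured value, while the other entry is a limit (the limit of > 44800 nM in this assay, at which 1 of the 2 values shown sits); no step between measured compounds is known, and compound 1 differs from compound 2 in more than one place, so the two values show no more than this.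

Compound 3 `COc1cc(OC)c2c(=O)cc(C(=O)Nc3ccc(S(=O)(=O)c4ccccc4)cc3)[nH]c2c1` is not yet measured. It differs from compound 2 in one place: phenylsulfonyl in place of 4-nitrophenoxy on an aromatic carbon, the phenylsulfonyl in place of 4-nitrophenoxy on an aromatic carbon, para to a large group.

Among the compounds with values here, with no measured step to rest on, the expectation for compound 3 is a change not beyond the usual scatter, in either direction, in this assay; the step from compound 2 to compound 3 is estimated as a 1.0-fold lower number from compound 2 to compound 3 (0.01 log units; within the scatter). Compound 3 is thus estimated at 20000 nM, within a range from 7000 nM to 60000 nM.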

Compound 3, half-maximal effective concentration: > 70600 nM
Compound 3 gave a limit, no number; the forecaster's own chance of this, stated with the estimate: 30%; at least 3.5-fold (0.54 log units) between middle value and limit.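

In this assay, the place on an aromatic carbon, para to a large group, now has its first readable step, which the two earlier compounds could not give: phenylsulfonyl in place of 4-nitrophenoxy brings an at least 3.4-fold higher number from compound 2 to compound 3 (0.53 log units; beyond the scatter). The shared core and the amide are unchanged across this pair, so the step belongs to this one exchange and shows that the group at this place matters for the read-out, with 4-nitrophenoxy giving the lower number. The entry for compound 3 is a limit of the assay and not a number, so the step is known from one side only: the limit of > 70600 nM in this assay, at which 1 of the 3 values shown sits.

Nothing shown here gives a measured property that would explain the change.

As far as these compounds go, how large the step truly is stays open, as does whether the difference follows the ring substituent or the link to the shared core. A plain phenoxy, a 4-aminophenoxy or a benzoyl group at this place would begin to separate those parts of the exchange, and the compounds shown say nothing about any of them.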